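A few compounds are considered here, and "the series" means these few. Any claim that something is new, unique, unknown or untested is made for them only; others in the source may bear on it.

Three compounds have been measured in a functional assay on HepG2 cells (Homo sapiens) for cytotoxicity, read by MTT assay, with a stated time of 72 h; on this read-out higher numbers stand for weaker inhibition and lower numbers for stronger inhibition:

Compound 1, `Cc1cc(=O)n(-c2ccccc2C(F)(F)F)nc1C(=O)Nc1ccc(Oc2ncnc3ccsc23)c(F)c1`, gives 9380 nM.
Compound 2, `Cc1cc(=O)n(-c2ccccc2C(F)(F)F)nc1C(=O)Nc1ccc(Oc2ncnc3sccc23)cc1`, reaches only a limit of the assay, > 40000 nM.
Compound 3, `Cc1cc(=O)n(-c2ccccc2C(F)(F)F)nc1C(=O)Nc1ccc(Oc2ncnc3sccc23)c(F)c1`, gives 14700 nM.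

Among the numbers shown, compound 3 holds the highest value, and its nearest neighbour is compound 1; the step of a 1.6-fold higher number from compound 1 to compound 3 (0.20 log units; within the scatter) lies within the scatter, so the two cannot be told apart. For compound 2 only a limit is known (the limit of > 40000 nM in this assay, at which 1 of the 3 values shown sits). The step of an at least 2.7-fold lower number from compound 2 to compound 3 (0.43 log units; beyond the scatter) counts as at least modest.

Compound 4, `Cc1ccc(-n2nc(C(=O)Nc3ccc(Oc4ncnc5sccc45)c(F)c3)c(C)cc2=O)cc1`, has not yet been measured. It differs from compound 3 in one place: 4-methylphenyl in place of 2-(trifluoromethyl)phenyl on an aromatic nitrogen. Neither measured step touches this part of the molecule. The step between compound 1 and compound 3 exchanges the bicyclic group on the ether oxygen, and the step between compound 2 and compound 3 adds a fluoro to a different ring. The measured data therefore give no guidance on how this assay responds to the change at the aromatic nitrogen, and no step beyond the scatter is expected in either direction. Compound 4 is estimated at 15000 nM, with a range from 4000 nM to 50000 nM. The expected step of a 1.0-fold higher number from compound 3 to compound 4 (0.01 log units; within the scatter) is accordingly none beyond the scatter.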

Compound 4, half-maximal inhibitory concentration: > 40000 nM
Compound 4: only a limit was reported; the forecaster's own chance of this, stated with the estimate: 25%; middle value at least 2.6-fold (0.42 log units) from the limit.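

In this assay, putting 4-methylphenyl in place of 2-(trifluoromethyl)phenyl on the aromatic nitrogen gives an at least 2.7-fold higher number from compound 3 to compound 4 (0.43 log units; beyond the scatter), so this position, untouched by the other steps shown, does affect the read-out. Since a higher number stands for weaker inhibition, the 2-(trifluoromethyl)phenyl compound is the more cytotoxic of this pair, and the true size of the step may be larger than printed. Compound 4 gives only a limit and not a number, as does compound 2: the limit of > 40000 nM in this assay, at which 2 of the 4 values shown sit.

This single swap changes both the substituent on the phenyl ring and its place on that ring, so the compounds shown cannot tell whether trifluoromethyl versus methyl or the place of the group accounts for the step. On these data alone, how 2-methylphenyl, 4-(trifluoromethyl)phenyl or plain phenyl would behave on this nitrogen stays open, as does whether the same swap would have a similar effect on the core of compound 1.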